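This account rests on a few compounds, and the source may have more. Where it says the series, first, only, none or still open, it means among the compounds named here.

Measured in a functional assay on HEK293 cells for antagonist activity at transient receptor potential cation channel subfamily V member 1 (Rattus norvegicus), read by calcium flux; on this read-out lower numbers stand for stronger inhibition and higher numbers for weaker inhibition:

compound 1, `CSc1ccc(Nc2ncnc3sc(Nc4c(Cl)cccc4Cl)nc23)cc1`: 12 nM
compound 2, `CS(=O)(=O)c1ccc(Nc2ncnc3sc(Nc4c(Cl)cccc4Cl)nc23)cc1`: 3 nM
compound 3, `CSc1nc(Nc2ccc(C(F)(F)F)c(Cl)c2)c2nc(Nc3c(Cl)cccc3Cl)sc2n1`: 113 nM

Compounds 1 and 2 share one core and differ only in one place: methylsulfonyl in place of methylsulfanyl on an aromatic carbon. In this assay this gave a 4.0-fold lower number from compound 1 to compound 2 (0.60 log units; beyond the scatter). Compound 3 carries a different core; how the core of compound 3 differs from the core of compound 1 is not broken down here. In this assay compound 3 gives 113 nM, the highest number of the three measured.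

Compound 4, `CS(=O)(=O)c1nc(Nc2ccc(C(F)(F)F)c(Cl)c2)c2nc(Nc3c(Cl)cccc3Cl)sc2n1`, is not yet measured. It relates to compound 3 by the same kind of change as compound 2 relates to compound 1: methylsulfonyl in place of methylsulfanyl on an aromatic carbon. The surroundings of the place are not the same: in compound 1 the group sits on a six-membered aromatic ring of carbon only, para to a large group, whereas in compound 3 it sits on a six-membered aromatic ring with 2 nitrogen, part of a fused or bridged system of two rings, between two ring nitrogen atoms, meta to a fused ring, meta to a large group and para to a fused ring. The change is thus of the same kind but not the same.

Within the data shown here, only one example of this change is measured, and it stands on a different core, so the expectation for compound 4 rests on a single step. Because a 4.0-fold lower number from compound 1 to compound 2 (0.60 log units; beyond the scatter) lies beyond the scatter, a lower number than for compound 3 is expected for compound 4, but with the place so different a smaller step is assumed and the range is kept wide. The expected step is a 2.3-fold lower number from compound 3 to compound 4 (0.35 log units; beyond the scatter). In this assay compound 4 is estimated at 50 nM, with a range from 15 nM to 170 nM.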

Compound 4, half-maximal inhibitory concentration: 77 nM
The estimate for compound 4 lay 1.5-fold (0.19 log units) below the measured number; measured number inside the range.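

In this assay, methylsulfonyl in place of methylsulfanyl on the second core gives a 1.5-fold lower number from compound 3 to compound 4 (0.17 log units; within the scatter), so on this core the change cannot be told from the scatter of repeated measurements. The step seen on the core of compound 1 therefore does not carry over at the same size to the core of compound 3: the same change on two cores in this assay, a 4.0-fold lower number (0.60 log units; beyond the scatter) from compound 1 to compound 2 and a 1.5-fold lower number (0.17 log units; within the scatter) from compound 3 to compound 4, 2.7-fold (0.44 log units) apart, beyond the scatter of two such steps This rests on one pair per core and does not show which difference between the cores goes with the gap, since the place of the change, on a six-membered aromatic ring with 2 nitrogen rather than one of carbon only, differs along with the rest of the molecule.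

The compounds shown leave open how other groups behave at the place between two ring nitrogen atoms, for example an amine, a methoxy group or a nitrile, and so whether that place responds to any exchange in this assay. Also open, as far as these compounds go, is whether a carboxylic acid or an amide on the ring of carbon only in the core of compound 1 would follow the step seen there with methylsulfonyl.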